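This account rests on a few compounds, and the source may have more. Where it says the series, first, only, none or still open, it means among the compounds named here.

Measured in a functional assay on CCRF-CEM cells (Homo sapiens) for cytotoxicity, with a stated time of 72 h; on this read-out higher numbers stand for weaker inhibition and lower numbers for stronger inhibition:
- Compound 1 `CCOC(=O)/C=C/C=C/c1ccc[nH]1`: > 10000 nM, a limit of the assay and not a number.
- Compound 2 `CCOC(=O)/C=C/C=C/C=C/c1ccc[nH]1`: 3670 nM.

Among the compounds with values here, compound 2 gives the only actual number so far in this assay, so it has no numerical comparison. Compound 3 `CCOC(=O)/C=C/C=C/C=C/c1ccco1` differs from compound 2 as follows: furan-2-yl in place of 1H-pyrrol-2-yl on a double-bonded chain carbon bound to a double-bonded chain carbon, with furan-2-yl in place of 1H-pyrrol-2-yl on a double-bonded chain carbon bound to a double-bonded chain carbon. Within the data shown here, no measured pair shows the effect of this exchange, so the expectation is tentative. The expected 1.2-fold higher number from compound 2 to compound 3 (0.09 log units; within the scatter) is small and towards weaker inhibition. For compound 3 the estimated value is 4500 nM, with an expected range of 1500 nM to 12000 nM.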

Compound 3, half-maximal inhibitory concentration: > 10000 nM
Compound 3 was reported as a limit; the forecaster's own chance of this, stated with the estimate: 25%; at least 2.2-fold (0.34 log units) between middle value and limit.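

Furan-2-yl in place of 1H-pyrrol-2-yl on a double-bonded chain carbon bound to a double-bonded chain carbon is the first readable exchange at this position, and it weakens inhibition: an at least 2.7-fold higher number from compound 2 to compound 3 (0.43 log units; beyond the scatter) in this series. The two five-membered aromatic rings are therefore not interchangeable here, and only the 1H-pyrrol-2-yl compound 2 gives a number. The step has only a lower bound: the limit of > 10000 nM in this assay, at which 2 of the 3 values shown sit.

From the compounds shown here alone, the exchange removes a hydrogen-bond donor and adds an acceptor, so it remains open which of these changes matters, or whether the ring hetero atom itself does. A 1-methyl-1H-pyrrol-2-yl or thiophen-2-yl group at this place would help separate these possibilities.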